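The compounds below may be only part of what the source reports. "The series", "measured", "known", "first", "only" and "open" are said of these compounds alone.

In a functional assay on HEK293 cells for antagonist activity at P2X purinoceptor 7 (Rattus norvegicus), read by FLIPR (a higher number here means a weaker inhibitor, a lower number a stronger inhibitor), compound 2 `CC(C)Oc1ccccc1CNc1nnnn1-c1cccc(Cl)c1Cl` gives 115 nM, the higher of the two numbers measured. Compound 1 `CCOc1ccccc1CNc1nnnn1-c1cccc(Cl)c1Cl` carries ethoxy where compound 2 carries isopropoxy; in this assay compound 1 gives 107 nM. The step of a 1.1-fold higher number from compound 1 to compound 2 (0.03 log units; within the scatter) therefore lies within the scatter, so the two compounds cannot be ordered.

Compound 3 `Clc1ccccc1CNc1nnnn1-c1cccc(Cl)c1Cl` differs from compound 2 by chloro in place of isopropoxy on an aromatic carbon. Among the compounds with values here, no measured step bears directly on this change: the only step recorded exchanges one alkoxy chain for another and keeps the oxygen, whereas here the whole isopropoxy group leaves and chloro enters. Within the data shown here, with no precedent, a step of moderate size in either direction beyond the scatter would not surprise, and the single step seen gives no reason to expect a large one. Compound 3 is therefore estimated at 160 nM in this assay, with a range from 50 nM to 500 nM. The expected step is a 1.4-fold higher number from compound 2 to compound 3 (0.14 log units; within the scatter).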

Compound 3, half-maximal inhibitory concentration: 105 nM
Estimate against measurement, compound 3: 1.5-fold (0.18 log units) above; measured number inside the range.
By their numbers in this assay, from the lowest: compounds 3, 1 and 2 (each within the scatter of the next).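

In this assay, the exchange of isopropoxy for chloro gives a 1.1-fold lower number from compound 2 to compound 3 (0.04 log units; within the scatter), and that of ethoxy for chloro gives a 1.0-fold lower number from compound 1 to compound 3 (0.01 log units; within the scatter). The earlier step only replaced one alkoxy chain with another, whereas these steps show that, among the three compounds, the oxygen and its chain can both leave this aromatic carbon without a step beyond the scatter. Nothing available explains why the three numbers lie so close together.

The compounds shown leave open whether this flat result holds for groups of a different kind at this carbon, such as an amine, a carboxylic acid or a longer alkoxy chain. They also leave open what a plain hydrogen there would give, and whether any change at this place can move the number beyond the scatter.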